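The compounds below may be only part of what the source reports. "The series", "measured", "known", "first", "only" and "open" are said of these compounds alone.

Measured in a functional assay on MT4 cells (Homo sapiens) for cytotoxicity; on this read-out higher numbers stand for lower toxicity in this test and lower numbers for higher toxicity in this test:
- compound 1 `C=C1CN(S(=O)(=O)c2ccc(Br)cc2)CCCN(C(=O)OCC)CCCN(S(=O)(=O)c2ccc(Br)cc2)C1`: 29000 nM
- compound 2 `C=C1CN(S(=O)(=O)c2ccc(OC)cc2)CCCN(CCC(C)C)CCCN(S(=O)(=O)c2ccc(OC)cc2)C1`: 53000 nM
- compound 3 `C=C1CN(S(=O)(=O)c2ccc(OC)cc2)CCCN(Cc2ccccc2)CCCN(S(=O)(=O)c2ccc(OC)cc2)C1`: 26000 nM

Compound 3 gives the lowest of the three numbers in this assay; its gap to compound 1 lies within the scatter, while compound 2 sits clearly higher. Going by the values given here, the only step measured so far, a 2.0-fold lower number from compound 2 to compound 3 (0.31 log units; beyond the scatter), concerns the group on the central ring nitrogen and is modest in size.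

Compound 4 `C=C1CN(S(=O)(=O)c2ccc(OC)cc2)CCCNCCCN(S(=O)(=O)c2ccc(OC)cc2)C1` differs from compound 3 in one place: hydrogen in place of benzyl on an amine nitrogen in a ring. Among the compounds with values here, no measured step removes a substituent from this nitrogen outright, so the only guidance is that the isobutyl-to-benzyl exchange at the same position moved the number only modestly. On that basis a small step is expected in this assay, more likely toward a higher number than a lower one, but not certainly beyond the scatter. Compound 4 is therefore estimated at 36000 nM, with a range of 15000 nM to 85000 nM, which corresponds to an expected step of a 1.4-fold higher number from compound 3 to compound 4 (0.14 log units; within the scatter).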

Compound 4, half-maximal cytotoxic concentration: 43000 nM
Estimate against measurement, compound 4: 1.2-fold (0.08 log units) below; measured number inside the range.
By their numbers in this assay, from the lowest: compounds 3, 1, 4 and 2 (each within the scatter of the next, the first and the last beyond it).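

In this assay this position is now seen with no group on the ring nitrogen, and taking the group away gives no step beyond the scatter: a 1.7-fold higher number from compound 3 to compound 4 (0.22 log units; within the scatter) for loss of benzyl and a 1.2-fold lower number from compound 2 to compound 4 (0.09 log units; within the scatter) for loss of isopentyl on the same nitrogen. Compound 4 therefore cannot be told apart from either substituted compound, even though the two are themselves separated by a 2.0-fold lower number from compound 2 to compound 3 (0.31 log units; beyond the scatter) at this position. Neither benzyl nor isopentyl is thus shown to change the read-out relative to hydrogen, and no measurement on hand accounts for these small steps.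

Still open, from the compounds shown here alone, is how this nitrogen behaves with an acetyl group, an aminoethyl chain or a carboxylic acid on a longer chain. Also open, going by these compounds, is whether the hydrogen step holds with the 4-bromophenylsulfonyl groups of compound 1.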